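Dropping a chloro group from the ring of compound 1

The source may hold more compounds than are shown below. What is called first, only, known or untested is meant among the compounds shown, and "the series" means these compounds.

Compound 1 `CS(=O)(=O)c1ccc(Cc2n[nH]c(=S)n2/N=C/c2c(F)cccc2Cl)cc1` carries a 2-chloro-6-fluorophenyl on the carbon that is double-bonded to nitrogen. In a functional assay on HeLa cells (Homo sapiens) for cytotoxicity, read by MTT assay, with a stated time of 48 h, tested at 100 uM (on this read-out higher numbers stand for a stronger effect at the one concentration tested and lower numbers for a weaker effect), compound 1 gives 77.3%, the highest of the three numbers measured. Compound 2 `CSc1ccc(/C=N/n2c(Cc3ccc(S(C)(=O)=O)cc3)n[nH]c2=S)cc1` gives 71.9%, and the step of a number 5.4 percentage points lower from compound 1 to compound 2 (within the scatter) stays within the scatter. Compound 3 `CS(=O)(=O)c1ccc(Cc2n[nH]c(=S)n2/N=C/c2ccc(Cl)cc2)cc1` gives 57%, and the step of a number 20.3 percentage points lower from compound 1 to compound 3 (beyond the scatter) is a modest loss beyond the scatter. Between those two, a number 14.9 percentage points lower from compound 2 to compound 3 (beyond the scatter) is likewise a modest loss.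

Compound 4 `CS(=O)(=O)c1ccc(Cc2n[nH]c(=S)n2/N=C/c2ccccc2F)cc1` differs from compound 1 in one place: hydrogen in place of chloro on an aromatic carbon. Cut one bond further out, the 2-chloro-6-fluorophenyl becomes 2-fluorophenyl. Among the measured compounds shown here, no measured step removes exactly this chloro group while the fluoro group stays; the two steps from compound 1 exchange the whole ring. Because a number 5.4 percentage points lower from compound 1 to compound 2 (within the scatter) is small and a number 20.3 percentage points lower from compound 1 to compound 3 (beyond the scatter) is only modest, a change that keeps most of the ring is expected to cost little or a modest amount in this assay. The step is therefore estimated as a number 11.3 percentage points lower from compound 1 to compound 4 (beyond the scatter). For compound 4 the estimated value is 66%, with a range from 50% to 80%.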

Compound 4, a percentage reported as activity, at one concentration (the size of the read-out at that concentration, not a potency): 28.1%
Estimate against measurement, compound 4: 37.9 percentage points above; the measured number lies below the stated range.
By their numbers in this assay, from the lowest: compound 4; then compound 3; then compounds 2 and 1 (each within the scatter of the next).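

In this assay, removing the chloro group alone, a change of one heavy atom, gives a number 49.2 percentage points lower from compound 1 to compound 4 (beyond the scatter), a large step and a bigger loss than either earlier exchange of the whole ring from compound 1. The 2-fluorophenyl also falls short of both other rings, with a number 28.9 percentage points lower from compound 3 to compound 4 (beyond the scatter) and a number 43.8 percentage points lower from compound 2 to compound 4 (beyond the scatter), which places compound 4 lowest of the four compounds on this read-out. A chloro group on the ring is not required for a high number, however: compound 2 has a 4-(methylsulfanyl)phenyl in that place and no chlorine, so what this step shows is that the chloro group matters within the 2-chloro-6-fluorophenyl, not that chlorine is needed in every ring.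

No measurement shown here explains why losing this one atom has so large an effect. From the compounds shown here alone, it also remains open whether a bromo, methyl or methoxy group on that aromatic carbon would restore the number seen for compound 1, and what would happen if the fluoro group were removed and the chloro group kept.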